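A few compounds are considered here, and "the series" means these few. Any claim that something is new, unique, unknown or untested is made for them only; others in the source may bear on it.

Series notes. Compound 1 `COC(=O)c1c[nH]c2cc(Oc3ccccc3)ccc2c1=O` carries phenoxy on the shared core; in an ADME assay on J774 cells (Mus musculus) for cytotoxicity (on this read-out higher numbers stand for an effect only at larger amounts of compound and lower numbers for an effect already at smaller amounts), compound 1 gives 9120 nM. Compound 2 `COC(=O)c1c[nH]c2cc(-c3ccccc3)ccc2c1=O` carries phenyl in the same position. In this assay compound 2 reaches only the limit of the assay, > 20000 nM. The change from compound 2 to compound 1 is phenoxy in place of phenyl on an aromatic carbon; the step it made is an at least 2.1-fold lower number from compound 2 to compound 1 (0.34 log units; beyond the scatter), which rests on (the limit of > 20000 nM in this assay, at which 2 of the 3 values shown sit). Compound 3 `COC(=O)c1c[nH]c2ccc(-c3ccccc3)cc2c1=O` is built on a different core, and the difference between the two cores is not broken down here. In this assay compound 3 also sits at the limit of the assay, > 20000 nM, so for compound 3 only a limit is known. Compound 4 `COC(=O)c1c[nH]c2ccc(Oc3ccccc3)cc2c1=O` is the phenoxy partner of compound 3, made by phenoxy in place of phenyl on an aromatic carbon, the same change as from compound 2 to compound 1. In this assay the step from compound 3 to compound 4 is expected to be an at least 1.6-fold lower number from compound 3 to compound 4 (0.22 log units; that floor lies within the scatter), resting on the step of an at least 2.1-fold lower number from compound 2 to compound 1 (0.34 log units; beyond the scatter) and on the limit of compound 3 > 20000 nM. Compound 4 is estimated at 12000 nM, from 5000 nM to 25000 nM, with a real chance that only a limit is reported.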

Compound 4, half-maximal effective concentration: > 20000 nM
Compound 4 gave a limit, no number; the forecaster's own chance of this, stated with the estimate: 40%; at least 1.6-fold (0.22 log units) between middle value and limit.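

No step from compound 3 to compound 4 can be read in this assay, because both compounds stand only at a limit: the limit of > 20000 nM in this assay, at which 3 of the 4 values shown sit.

The compounds shown leave open whether phenoxy in place of phenyl on an aromatic carbon lowers the number on the core of compound 3, as it does on the core of compound 1.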